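This account rests on a few compounds, and the source may have more. Where it says the series, first, only, none or still open, it means among the compounds named here.

Compound 3 `COC(=O)[C@H](CCSC)NC(=O)c1ccc(NCc2cncn2Cc2cccc(C)c2)cc1-c1ccccc1` was tested in a functional assay on NIH3T3 cells (Mus musculus); a higher number here means that more compound is needed for the effect, a lower number that less compound is needed. In this assay compound 3 gives > 10 uM, which is a limit of the assay and not a number. Two companions share its core and differ from it only in the group carried on the same chain carbon. In this assay compound 1 `COC(=O)[C@H](CCSC)NC(=O)c1ccc(NCc2cncn2Cc2cccc([N+](=O)[O-])c2)cc1-c1ccccc1` gives > 10 uM, again a limit. In this assay compound 2 `COC(=O)[C@H](CCSC)NC(=O)c1ccc(NCc2cncn2Cc2cccc(Cl)c2)cc1-c1ccccc1` gives > 10 uM, also a limit. The steps among these three, a step that the two limits leave unreadable from compound 1 to compound 2, a step that the two limits leave unreadable from compound 1 to compound 3 and a step that the two limits leave unreadable from compound 2 to compound 3, cannot be read in size because of the limit of > 10 uM in this assay, at which 3 of the 3 values shown sit. Compound 4 `COC(=O)[C@H](CCSC)NC(=O)c1ccc(NCc2cncn2Cc2ccccc2C)cc1-c1ccccc1` has not yet been measured. It differs from compound 3 by 2-methylphenyl in place of 3-methylphenyl on a saturated chain carbon bound to an aromatic nitrogen. All three measured steps bear on this change, since each swaps one small group for another on the same benzyl carbon, and none of them brought any compound within reach of the assay. Going by the values given here, nothing in these data therefore points to a step beyond the scatter in either direction, and no member of the set has yet given a number. Compound 4 is expected to give 15 uM, from 5 uM to 50 uM. The estimated step from compound 3 is a step that the limit leaves unreadable from compound 3 to compound 4, which is expected to mean no change beyond the scatter.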

Compound 4, concentration for half-maximal effect: > 10 uM
Compound 4 ended at the assay's limit (the forecaster's own chance of this, stated with the estimate: 80%); the middle value is on the limit's open side.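

In this assay compound 4 gives > 10 uM, which is a limit and not a number. Its steps to compound 1, compound 2 and compound 3 cannot be read in size because of where all the values sit: the limit of > 10 uM in this assay, at which 4 of the 4 values shown sit. The compounds shown leave open whether 2-methylbenzyl, 3-methylbenzyl or the other benzyl groups differ at all in this assay.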